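From Methylsulfonyl to a Tetrazolyl Amide on the Chain

The source may report more compounds than this note shows. Statements on the series, on what has been measured and on what is new or still open speak of the compounds shown alone.

Compound 1 `CCc1cc(C(C)=O)c(O)cc1OCCCCCC(C)(C)C#N` gives 53% in an assay on isolated protein for binding affinity to leukotriene B4 receptor 1 (Homo sapiens), tested at 1 uM; a lower number here means less inhibition, a higher number more inhibition at the concentration tested (going by the name of the read-out).
Compound 2 `CCc1cc(C(C)=O)c(O)cc1OCCCCCC(C)(C)C(=O)O` gives 73% in this assay.
Compound 3 `CCc1cc(C(C)=O)c(O)cc1OCCCCCCS(C)(=O)=O` gives 62% in this assay.

Compound 3 stands second highest of the three numbers. Its nearest neighbour is compound 1, with a number 9 percentage points higher from compound 1 to compound 3 (within the scatter), while against compound 2 it reads a number 11 percentage points lower from compound 2 to compound 3 (beyond the scatter).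

Compound 4 `CCc1cc(C(C)=O)c(O)cc1OCCCCCCC(=O)Nc1nn[nH]n1` has not yet been measured. It differs from compound 3 in one place: (2H-tetrazol-5-yl)carbamoyl in place of methylsulfonyl on a saturated chain carbon, six bonds along the chain from an oxygen on an aromatic ring.

Going by the values given here, two measured steps bear on this change. The step of a number 20 percentage points higher from compound 1 to compound 2 (beyond the scatter) shows that a carboxy end of the chain gave the highest number of the set, and the step of a number 11 percentage points lower from compound 2 to compound 3 (beyond the scatter) shows that the methylsulfonyl end of compound 3 fell modestly short of it. Among the compounds with values here, no measured step puts a tetrazolyl amide at the chain end, so the expectation rests only on this loose analogy. Compound 4 is expected to rise modestly over compound 3, by a number 13 percentage points higher from compound 3 to compound 4 (beyond the scatter), to an estimated 75%, within a range from 55% to 92%.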

Compound 4, a percentage reported as inhibition, at one concentration (the size of the read-out at that concentration, not a potency): 83%
The estimate for compound 4 lay 8 percentage points below the measured number; the measured number falls inside the stated range.
By their numbers in this assay, from the lowest: compounds 1 and 3 (each within the scatter of the next); then compounds 2 and 4 (each within the scatter of the next).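

In this assay, going by these compounds alone, the change at this place, on a saturated chain carbon six bonds along the chain from an oxygen on an aromatic ring, gives a number 21 percentage points higher from compound 3 to compound 4 (beyond the scatter), which shows that this end of the chain accepts a five-membered aromatic ring with 4 hetero atoms, a feature none of the earlier compounds carried. The comparison with the carboxy compound gives a number 10 percentage points higher from compound 2 to compound 4 (within the scatter), so the two ends cannot be told apart here, whereas the comparison with the nitrile compound gives a number 30 percentage points higher from compound 1 to compound 4 (beyond the scatter). No evidence is available to explain these differences. From the compounds shown here alone, what remains open is how a straight-chain carboxylic acid without the two methyl groups would read, since the step from compound 2 also removes those methyls. Going by these compounds, a tetrazole set directly on the chain, without the amide, and a longer chain also remain open.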